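The source may report more compounds than this note shows. Statements on the series, on what has been measured and on what is new or still open speak of the compounds shown alone.

Of the compounds shown here, three of one series have been measured in a functional assay (blood) for inhibition, with Homo sapiens as the target; on this read-out higher numbers stand for weaker inhibition and lower numbers for stronger inhibition. Compound 1 `C/C(=N\OCCSc1nnc(C)s1)c1ccc(Sc2cc(F)cc(C3CCOCC3)c2)cc1` gives 230 nM. Compound 2 `CC(C)/C(=N\O)c1ccc(Sc2cc(F)cc(C3CCOCC3)c2)cc1` gives 300 nM, and compound 3 `C/C(=N\OCC(O)CO)c1ccc(S(=O)(=O)c2cccc(C3CCOCC3)c2)cc1` gives 160 nM. Compound 1 thus sits second highest of the three numbers, but its gap to compound 2 and its gap to compound 3 both lie within the scatter of repeated measurement, so the three read as one level rather than as an order. The unmeasured compound 4 `C/C(=N\O)c1ccc(Sc2cc(F)cc(C3CCOCC3)c2)cc1` differs from compound 1 at the oxygen bound to the double-bonded nitrogen: hydrogen in place of 2-((5-methyl-1,3,4-thiadiazol-2-yl)sulfanyl)ethyl on an oxygen. Compound 2 carries the same hydroxy at that position and gives 300 nM, a number close to that of compound 1. The step of a 1.2-fold higher number from compound 1 to compound 4 (0.09 log units; within the scatter) is therefore expected to be small, in no settled direction, and not beyond the scatter. Compound 4 is expected to give about 280 nM in this assay, with a range from 100 nM to 800 nM.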

Compound 4, half-maximal inhibitory concentration: 80 nM
Compound 4: the middle estimate sits 3.5-fold (0.54 log units) above what was measured; the whole stated range lies above it.
By their numbers in this assay, from the lowest: compounds 4, 3, 1 and 2 (each within the scatter of the next, the first and the last beyond it).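

In this assay, the change on the oxygen bound to the double-bonded nitrogen, hydrogen in place of 2-((5-methyl-1,3,4-thiadiazol-2-yl)sulfanyl)ethyl, gives a 2.9-fold lower number from compound 1 to compound 4 (0.46 log units; beyond the scatter) and so goes with stronger inhibition, which shows that this position is not indifferent to the group it carries. The hydroxy alone does not settle the level, since methyl in place of isopropyl on the carbon with a double bond to nitrogen gives a 3.8-fold lower number from compound 2 to compound 4 (0.57 log units; beyond the scatter) with the hydroxy present on both sides of the step. Nothing available explains either step.

Going by these compounds, it remains open whether a small ether such as methoxy on that oxygen, or a longer chain ending in an amine or a carboxylic acid, would stay near compound 4 or fall back towards compound 1. Ethyl on the carbon with a double bond to nitrogen also remains open, so it cannot yet be said how the level changes between methyl and isopropyl.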